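This account rests on a few compounds, and the source may have more. Where it says the series, first, only, none or still open, it means among the compounds named here.

Working notes on the series. Three compounds have numbers in an assay on CHO cells for displacement of a labelled ligand from 5-hydroxytryptamine receptor 7 (Homo sapiens); a higher number here means a weaker inhibitor, a lower number a stronger inhibitor. Compound 1 `CCC1(CCCCN2CCN(c3cccc(Cl)c3)CC2)C(=O)Nc2c(Cl)cc(Cl)cc21` gives 9.46 nM and compound 2 `CC(C)CC1(CCCCN2CCN(c3cccc(Cl)c3)CC2)C(=O)Nc2ccccc21` gives 1.8 nM. Compound 3 `CCC1(CCCCN2CCN(c3ccc(OC)cc3)CC2)C(=O)Nc2ccccc21` gives 25.4 nM, the highest of the three; its nearest neighbour on the numbers is compound 1, and compound 2 lies furthest from it, both gaps beyond the scatter. Going by the values given here, compounds 1 and 2 each differ from compound 3 in more than one place, so no single-change step between measured compounds is available, and their values are read only as they stand.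

Compound 4 `CCC1(CCCCN2CCN(c3cccc(OC)c3)CC2)C(=O)Nc2ccccc21` is the next compound, differing from compound 3 by 3-methoxyphenyl in place of 4-methoxyphenyl on an amine nitrogen in a ring. With no measured step of this kind in the set, the size of the step in this assay can only be expected, not read off. A modest step toward a lower number is expected, likely within or just beyond the scatter, expressed as a 1.7-fold lower number from compound 3 to compound 4 (0.23 log units; within the scatter). Compound 4 is therefore estimated at 15 nM in this assay, with a range from 5 nM to 45 nM.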

Compound 4, inhibition constant: 2.55 nM
For compound 4 the middle estimate is 5.9-fold (0.77 log units) above the measured one; the measured number lies below the stated range.
By their numbers in this assay, from the lowest: compounds 2 and 4 (each within the scatter of the next); then compound 1; then compound 3.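

In this assay the change to 3-methoxyphenyl in place of 4-methoxyphenyl on the amine nitrogen in the ring gives a 10-fold lower number from compound 3 to compound 4 (1.00 log units; beyond the scatter) with no change in the atoms or in the counts of donors and acceptors. Going by these compounds alone, this is the first single-change step, and it shows that at this place the arrangement of the methoxyphenyl group alone can move the number beyond the scatter, which the earlier compounds, differing in more than one place, could not show. No supporting measurement bears on why the step has this size.

Still open, from the compounds shown here alone, is whether a hydroxy or an ethoxy group in place of the methoxy would keep the number of compound 4. Also open, going by these compounds, is whether a step of this size would recur with a group other than ethyl on the shared core.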